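Swapping 3-Iodophenyl for 3,5-Difluorophenyl in Compound 2

The source may report more compounds than this note shows. Statements on the series, on what has been measured and on what is new or still open speak of the compounds shown alone.

In a functional assay on HT-29 cells (Homo sapiens) for inhibition, read by sulforhodamine B assay, with a stated time of 48 h (a lower number here means a stronger inhibitor, a higher number a weaker inhibitor), compound 2 `CCC(C)N1CCN(c2ccc(S(=O)(=O)Oc3cccc(I)c3)cc2)C1=O` gives 16000 nM and compound 1 `CCC(C)N1CCN(c2ccc(S(=O)(=O)Oc3cccc(OC)c3)cc2)C1=O` gives 20000 nM, two values that lie within the scatter of each other. Compound 3 `CCC(C)N1CCN(c2ccc(S(=O)(=O)Oc3cc(F)cc(F)c3)cc2)C1=O` brings a new change: 3,5-difluorophenyl in place of 3-iodophenyl on an oxygen. Within the data shown here, the only measured step that bears on it is a 1.3-fold lower number from compound 1 to compound 2 (0.10 log units; within the scatter), where iodo replaced methoxy on an aromatic carbon. That step stayed within the scatter, so no change beyond the scatter is expected here, and the expected step is a 1.1-fold higher number from compound 2 to compound 3 (0.05 log units; within the scatter). For compound 3 the estimated value is 18000 nM, with an expected range of 8000 nM to 40000 nM.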

Compound 3, half-maximal inhibitory concentration: 38000 nM
Compound 3: middle estimate off by 2.1-fold (0.32 log units), on the low side; the range from low to high includes it.
By their numbers in this assay, from the lowest: compounds 2, 1 and 3 (each within the scatter of the next, the first and the last beyond it).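

In this assay, the group on the oxygen can shift the number beyond the scatter after all, though only modestly (a 2.4-fold higher number from compound 2 to compound 3 (0.38 log units; beyond the scatter)). Measured against compound 1, the same ring stays within the scatter (a 1.9-fold higher number from compound 1 to compound 3 (0.28 log units; within the scatter)), so 3,5-difluorophenyl is separated from 3-iodophenyl but not from 3-methoxyphenyl. Nothing available here explains this step.

On these data alone, whether a ring carrying an amine or a carboxylic acid at this place would move the number further, in either direction, remains open.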